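A few compounds are considered here, and "the series" means these few. Any claim that something is new, unique, unknown or untested is made for them only; others in the source may bear on it.

Measured compounds in the series:
compound 1 `C#CCCOC(=O)/C=C(C)/C=C/CC(C)CCCC(C)(C)OC` with 5.2
compound 2 `CC(=O)OC(C)(C)CCCC(C)C/C=C/C(C)=C/C(=O)OC(C)C` with 5.98
compound 3 `CC(C)=CCCC(C)C/C=C/C(C)=C/C(=O)OC(C)C` with 6.6

In a physicochemical assay for lipophilicity (a higher number here means a more lipophilic compound, a lower number a more polar compound), compound 1 stands lowest of the three. Compound 2 lies nearest to it, and compound 3 furthest; both gaps are beyond the scatter, so compound 1 is the most polar of the measured set.

Among the measured compounds shown here, the only step between measured compounds, a number 0.62 log units higher from compound 2 to compound 3 (beyond the scatter), concerns a change on a saturated chain carbon four bonds along the chain from a double-bonded chain carbon. It says nothing about the carbonyl end of the chain and does not bear on the change considered here.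

Compound 4 `CCC(=O)/C=C(C)/C=C/CC(C)CCCC(C)(C)OC` differs from compound 1 by ethyl in place of (but-3-yn-1-yl)oxy on a carbonyl carbon, that is, ((but-3-yn-1-yl)oxy)carbonyl to propanoyl. The leaving group carries four carbon atoms, one oxygen and a triple bond; the entering ethyl carries two carbons and no oxygen. For the measured compounds named here, no measured pair in this set shows such a change, so the expectation rests on the loss of chain carbons alone. A step downward in this assay, of modest size, is expected, a number 0.50 log units lower from compound 1 to compound 4 (beyond the scatter).

Compound 4 is therefore estimated at 4.7, with a range from 4.2 to 5.2.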

Compound 4, partition coefficient: 5.07
Compound 4: middle estimate off by 0.37 log units, on the low side, and the stated range covers the measured number.
By their numbers in this assay, from the lowest: compounds 4 and 1 (each within the scatter of the next); then compound 2; then compound 3.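

On a carbonyl carbon whose other neighbour is a double-bonded chain carbon, ethyl in place of (but-3-yn-1-yl)oxy gives, in this assay, a number 0.13 log units lower from compound 1 to compound 4 (within the scatter). This is the only step shown at this position, and it places compound 1 and compound 4 within the scatter of each other even though the two groups differ in heavy atoms, oxygen and the triple bond, so for this pair the removal of chain carbons does not by itself set the read-out. No supporting data are available to explain this outcome.

A single pair cannot separate the contributions of the oxygen, the triple bond and the carbons that leave, and it cannot show whether the same exchange would give a comparable step in a compound carrying the 2-methylprop-1-en-1-yl or 2-acetoxy-2-methylpropyl group seen elsewhere in the series. Also open, going by these compounds, is how this assay would respond to a longer chain such as hexyl, or to an amine or a hydroxyl group, on the same carbonyl carbon.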